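The compounds below may be only part of what the source reports. "The series", "measured", "known", "first", "only" and "open" are said of these compounds alone.

Working notes on the thiazole-fused series read in an assay on HEK293 cells for positive allosteric modulation of metabotropic glutamate receptor 5 (Homo sapiens), read by FLIPR, with a stated time of 1 h; a lower number here means that less compound is needed, a higher number that more compound is needed for the effect.

Compound 1 `Fc1cccc(C#Cc2nc3c(s2)CN(C2CCOC2)CC3)c1` carries a fluorophenyl on the alkyne and an oxolanyl substituent on the ring nitrogen; in this assay compound 1 returns only a limit, > 10000 nM, and no number. That reading sits at the limit of > 10000 nM in this assay, at which 1 of the 2 values shown sits.

Compound 2 `O=C(C1CC12CCC2)N1CCc2nc(C#Cc3ccccc3)sc2C1` instead bears a plain phenyl on the alkyne and a carbonyl on the ring nitrogen, and in this assay compound 2 gives 3.9 nM. Among the values shown, compound 2 holds the only number; the one other reading is a limit, so no measured step between two numbers exists in the series yet.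

Compound 3 `O=C(N1CCCCC1)N1CCc2nc(C#Cc3ccccc3)sc2C1` is not yet measured. It keeps the core and the alkyne of compound 2 and differs only at the carbonyl carbon, where (a group of 6 heavy atoms (5 carbon, 1 nitrogen; one six-membered non-aromatic ring with 1 hetero atom) in place of a group of 6 heavy atoms (6 carbon; one three-membered non-aromatic ring of carbon only, one four-membered non-aromatic ring of carbon only), on a carbonyl carbon). The change swaps one group for another of equal heavy-atom count, with no donors or acceptors gained or lost.

Among the compounds with values here, with no measured step on record, the expectation for this assay is a modest weakening from compound 2 to compound 3, a 3.1-fold higher number from compound 2 to compound 3 (0.49 log units; beyond the scatter), with a loss still close to the scatter the more likely outcome. Compound 3 is estimated at 12 nM, within a range of 3 nM to 60 nM.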

Compound 3, half-maximal effective concentration: 75 nM
Compound 3: middle estimate off by 6.3-fold (0.80 log units), on the low side, and the stated range ends below it.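

Within the data shown here, at the carbonyl carbon whose other neighbour is the amide-type nitrogen in a ring, the first measured step shows that the group placed there matters: in this assay, piperidin-1-yl in place of the carbon-only group with a three-membered and a four-membered ring gives a 19-fold higher number from compound 2 to compound 3 (1.28 log units; beyond the scatter), a large step. Heavy-atom count stays the same and neither group carries donors or acceptors, so these counts alone do not set the reading at this place. The readings shown offer nothing that accounts for the size of this step.

One step cannot separate the entering ring nitrogen from the change in ring make-up, so cyclohexyl on the same carbonyl carbon would be the direct test of the nitrogen, while pyrrolidin-1-yl and morpholin-4-yl would show how the reading follows ring size and a second hetero atom. Also open, on these data alone, is whether a step of this size holds with a fluorophenyl rather than a plain phenyl on the alkyne, since both compounds in the step carry the plain phenyl.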